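Notes on the step from compound 3 to compound 4

This account rests on a few compounds, and the source may have more. Where it says the series, first, only, none or still open, it means among the compounds named here.

Measured in a functional assay on HT-29 cells (Homo sapiens) for antiproliferative activity, read by sulforhodamine B assay, with a stated time of 72 h; a lower number here means a stronger inhibitor, a higher number a weaker inhibitor:
- compound 1 `Cc1cccc(NC(=S)N/N=C/c2ccc3ccccc3n2)c1`: > 100000 nM, a limit
- compound 2 `S=C(N/N=C/c1ccc2ccccc2n1)Nc1ccc(Cl)cc1`: 97200 nM
- compound 3 `S=C(N/N=C/c1ccc2ccccc2n1)Nc1ccccc1Br`: > 100000 nM, a limit

Compound 3 stands at the limit of > 100000 nM in this assay, at which 2 of the 3 values shown sit, so only a limit is known for it. Compound 4 `S=C(N/N=C/c1ccc2ccccc2n1)Nc1cccc(Cl)c1` carries 3-chlorophenyl in place of 2-bromophenyl on an amide-type nitrogen. Three measured swaps at that nitrogen bear on this: an at least 1.0-fold lower number from compound 1 to compound 2 (0.01 log units; that floor lies within the scatter), an at least 1.0-fold higher number from compound 2 to compound 3 (0.01 log units; that floor lies within the scatter) and a step that the two limits leave unreadable from compound 1 to compound 3. None of them reads as a step beyond the scatter. The expected step in this assay is therefore a number no higher from compound 3 to compound 4 (the limit leaves the size open), with no change beyond the scatter expected. The estimate for compound 4 is 100000 nM, with an expected range of 40000 nM to 200000 nM.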

Compound 4, half-maximal inhibitory concentration: 48100 nM
For compound 4 the middle estimate is 2.1-fold (0.32 log units) above the measured one; the measured number falls inside the stated range.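

In this assay, going by these compounds alone, 3-chlorophenyl in place of 4-chlorophenyl on the amide-type nitrogen gives a 2.0-fold lower number from compound 2 to compound 4 (0.31 log units; beyond the scatter), the only step here between two measured numbers. 3-Chlorophenyl in place of 2-bromophenyl gives an at least 2.0-fold lower number from compound 3 to compound 4 (0.31 log units; beyond the scatter), and chloro in place of methyl on an aromatic carbon gives an at least 2.0-fold lower number from compound 1 to compound 4 (0.31 log units; beyond the scatter). Both of these steps rest on a limit rather than a number, for compound 1 and compound 3: the limit of > 100000 nM in this assay, at which 2 of the 4 values shown sit.

The effect of the halogen and that of its ring position remain unseparated in the step from compound 3, and 3-bromophenyl would bear on this. As far as these compounds go, what an aminophenyl group, a carboxyphenyl group or a longer chain on this nitrogen would give stays open.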